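Adding a Second Methoxy Group to Compound 1

The source may hold more compounds than are shown below. What is called first, only, known or untested is meant among the compounds shown, and "the series" means these compounds.

For the measured compounds named here, compound 1 `COc1ccc(-c2[nH]c3ccccc3c2/C=C(\C#N)S(=O)(=O)c2ccccc2)cc1` is one of three compounds measured in a functional assay on MOLT-4 cells (Homo sapiens) for inhibition, read by sulforhodamine B assay, with a stated time of 48 h; a higher number here means a weaker inhibitor of growth, a lower number a stronger inhibitor of growth. In this assay compound 1 gives 871 nM, the lowest of the three numbers. Compound 2 `COc1ccc2[nH]c(-c3ccccc3)c(C=C(C#N)C#N)c2c1` gives 3700 nM in this assay, and compound 3 `CCOC(=O)C(=Cc1c(-c2ccccc2)[nH]c2ccccc12)C(=O)OCC` gives 3900 nM. Both of these numbers lie beyond the scatter above that of compound 1, so compound 1 is the strongest growth inhibitor of the three.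

Compound 4 `COc1ccc(-c2[nH]c3ccc(OC)cc3c2/C=C(\C#N)S(=O)(=O)c2ccccc2)cc1` has not yet been measured in this assay. It differs from compound 1 in a single place: methoxy in place of hydrogen on an aromatic carbon. Going by the values given here, no measured pair in this small set carries exactly this change, so no step can be drawn from the data for it. Compound 2 also carries a methoxy on its core, yet it differs from compound 1 in more than one place, so what compound 2 shows at 3700 nM does not isolate that change.

With nothing closer to lean on, the step from compound 1 to compound 4 is expected to be modest, a 1.3-fold higher number from compound 1 to compound 4 (0.10 log units; within the scatter), most likely within the scatter or slightly toward a weaker inhibitor. Compound 4 is therefore estimated at 1100 nM in this assay, with a range from 450 nM to 2700 nM.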

Compound 4, concentration for 50% growth inhibition: 765 nM
The estimate for compound 4 lay 1.4-fold (0.16 log units) above the measured number, and the stated range covers the measured number.
By their numbers in this assay, from the lowest: compounds 4 and 1 (each within the scatter of the next); then compounds 2 and 3 (each within the scatter of the next).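

Methoxy in place of hydrogen, on an aromatic carbon of the six-membered aromatic ring of carbon only that is part of a fused system of two rings, meta to a fused ring and para to a fused ring, gives in this assay a 1.1-fold lower number from compound 1 to compound 4 (0.06 log units; within the scatter), so the two compounds cannot be told apart in their growth inhibition. For the compounds shown here, compound 2 also carries a methoxy on its core but differs from compound 1 in more than one place, so this pair is the first to isolate the change, and it shows that this position accepts a methoxy group with no shift beyond the scatter. Nothing available accounts for this result, and no measured property bears on it.

What the compounds shown leave open is whether this position would accept other groups equally well, such as an amine, a carboxylic acid or a longer chain in place of the methoxy. They also leave open whether a methoxy group at this place would read the same way in other cell lines, since only this one assay is shown.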